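This account rests on a few compounds, and the source may have more. Where it says the series, first, only, none or still open, it means among the compounds named here.

In a functional assay on U-937 cells (Homo sapiens) for cytotoxicity, read by MTT assay, with a stated time of 24 h (a higher number here means a weaker inhibitor, a lower number a stronger inhibitor), compound 1 `BrCCCCOc1c(Br)cc(Br)cc1Oc1ccc(Br)cc1Br` gives 29 ug/mL, compound 2 `CN1CCN(CCCCCOc2c(Br)cc(Br)cc2Oc2ccc(Br)cc2Br)CC1` gives 49.1 ug/mL and compound 3 `CC(=O)Oc1c(Br)cc(Br)cc1Oc1ccc(Br)cc1Br` gives 32.3 ug/mL, a value within the usual scatter of both others. Compound 4 `BrCCCCCOc1c(Br)cc(Br)cc1Oc1ccc(Br)cc1Br` comes from compound 3 by a single change, (5-bromopentyl in place of acetyl on an oxygen on an aromatic ring), with 5-bromopentyl in place of acetyl on an oxygen on an aromatic ring. The closest measured comparison puts acetyl in place of 4-bromobutyl on that oxygen, giving a 1.1-fold higher number from compound 1 to compound 3 (0.05 log units; within the scatter). Altering the end of the chain instead gave a 1.7-fold higher number from compound 1 to compound 2 (0.23 log units; within the scatter). Since neither step leaves the scatter, none beyond it is expected here. The expected step is a 1.0-fold lower number from compound 3 to compound 4 (0.00 log units; within the scatter). Compound 4 is estimated at 32 ug/mL, within an expected range of 18 ug/mL to 55 ug/mL.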

Compound 4, half-maximal inhibitory concentration: 29.5 ug/mL
The estimate for compound 4 lay 1.1-fold (0.04 log units) above the measured number; the measured number falls inside the stated range.
By their numbers in this assay, from the lowest: compounds 1, 4, 3 and 2 (each within the scatter of the next).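

On an oxygen on an aromatic ring, in this assay, 5-bromopentyl in place of acetyl stays within the scatter (a 1.1-fold lower number from compound 3 to compound 4 (0.04 log units; within the scatter)), even though the two groups share little beyond being attached there. Bromomethyl in place of bromo (a 1.0-fold higher number from compound 1 to compound 4 (0.01 log units; within the scatter)) and bromo in place of 4-methylpiperazin-1-yl (a 1.7-fold lower number from compound 2 to compound 4 (0.22 log units; within the scatter)) also stay within it, leaving these four compounds indistinguishable in this assay. No available evidence bears on this result. Going by these compounds, whether a carboxylic acid at the chain end, a simple amine or a longer chain would move the number beyond the scatter remains open.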